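The source may hold more compounds than are shown below. What is called first, only, known or untested is meant among the compounds shown, and "the series" means these compounds.

Compound 1 `CCC(C)(C)Cc1c[nH]c(CCc2ccc(-c3ccc(F)cn3)cc2)n1`; compound 2 `CCC(C)(C)Cc1c[nH]c(CCc2ccc(-c3cccnc3)cc2)n1`; compound 3 `CCC(C)(C)Cc1c[nH]c(CCc2ccc(-c3cccnc3C(=O)O)cc2)n1`.

Within the data shown here, in an in vitro assay on CHO cells for displacement of a labelled ligand from Bombesin receptor subtype-3 (Homo sapiens), read by scintillation counting, with a stated time of 2 h (a higher number here means a weaker inhibitor, a lower number a stronger inhibitor), compound 1 gives 19 nM and compound 2 gives 7.5 nM, the lower of the two numbers, the only measured step being a 2.5-fold lower number from compound 1 to compound 2 (0.40 log units; beyond the scatter). Compound 3 differs from compound 2 by carboxy in place of hydrogen on an aromatic carbon. Among the measured compounds shown here, no measured step touches this change, so the direction is uncertain and a wide range is appropriate. A modest weakening is estimated for compound 3, that is a 5.3-fold higher number from compound 2 to compound 3 (0.73 log units; beyond the scatter) in this assay. Compound 3 is therefore expected to give about 40 nM, in the range 8 nM to 200 nM.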

Compound 3, half-maximal inhibitory concentration: 560 nM
Estimate against measurement, compound 3: 14-fold (1.15 log units) below, outside the stated range (above it).
By their numbers in this assay, from the lowest: compound 2; then compound 1; then compound 3.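

In this assay, carboxy on this aromatic carbon, next to the ring nitrogen and ortho to a large group, brings a far larger loss than the earlier ring change, with a 75-fold higher number from compound 2 to compound 3 (1.87 log units; beyond the scatter) in a large step. The 2-carboxypyridin-3-yl group also compares poorly with 5-fluoropyridin-2-yl, with a 29-fold higher number from compound 1 to compound 3 (1.47 log units; beyond the scatter) as the result. No supporting measurement accounts for this loss. The compounds shown leave open whether a methyl ester or a primary amide at this position would behave like carboxy or stay closer to compound 2.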